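The source may hold more compounds than are shown below. What is called first, only, known or untested is meant among the compounds shown, and "the series" means these compounds.

Series on the shared core of compound 1 `COC(=O)c1scc(-c2ccc(NC(=O)c3ccc(OC)nc3)cc2)c1OC`, with compound 2 `COC(=O)c1scc(-c2ccc(NC(=O)c3ccccn3)cc2)c1OC` and compound 3 `COC(=O)c1scc(-c2ccc(NC(=O)c3ccc(C(F)(F)F)cc3)cc2)c1OC` as the two amide variants followed here. In an ADME assay on HEK293 cells (Homo sapiens) for cytotoxicity, read by MTT assay, with a stated time of 24 h (on this read-out lower numbers stand for stronger inhibition and higher numbers for weaker inhibition), compound 1 gives > 50000 nM, which is a limit of the assay. Compound 2 stands without a number: in this assay compound 2 gives "not determined" (no result reported). Among the measured compounds shown here, the only evidence so far is the limit of > 50000 nM in this assay, at which 1 of the 2 values shown sits. Compound 3 differs from compound 2 by 4-(trifluoromethyl)phenyl in place of pyridin-2-yl on a carbonyl carbon. For the measured compounds named here, no measured step from compound 2 sizes this change; in this assay a step within the usual scatter is expected, with a limit again the likely read-out. For compound 3 the estimate in this assay is 50000 nM, within 20000 nM to 100000 nM.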

Compound 3, half-maximal inhibitory concentration: 48300 nM
Beside the measured number, compound 3's estimate is 1.0-fold (0.02 log units) above it, within the range that was stated.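

Among the compounds shown here, on a carbonyl carbon, 4-(trifluoromethyl)phenyl gives the first real number for this position: in this assay compound 3 gives 48300 nM. Compound 1 stays a limit of the assay at > 50000 nM. The change of 6-methoxypyridin-3-yl to 4-(trifluoromethyl)phenyl gives an at least 1.0-fold lower number from compound 1 to compound 3 (0.01 log units; that floor lies within the scatter), so its true size remains unfixed.

Steps involving compound 2 cannot be read, since it has no number. Open, on these data alone, is what an amine or a carboxylic acid in place of trifluoromethyl on this phenyl ring would give in this assay.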